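The source may hold more compounds than are shown below. What is called first, only, known or untested is meant among the compounds shown, and "the series" means these compounds.

Measured so far in a functional assay on HL-60 cells (Homo sapiens) for antiproliferative activity, with a stated time of 24 h; on this read-out higher numbers stand for weaker inhibition and lower numbers for stronger inhibition:
compound 1, `NC(=O)c1c(NC(=O)c2ccccc2Cl)sc2c1CCN(Cc1ccccc1Cl)C2`, gives 2900 nM
compound 2, `NC(=O)c1c(NC(=O)c2ccccc2Cl)sc2c1CCN(Cc1ccccc1F)C2`, gives 21800 nM
compound 3, `NC(=O)c1c(NC(=O)c2ccccc2Cl)sc2c1CCN(C(=S)Nc1cc(C(F)(F)F)cc(C(F)(F)F)c1)C2`, gives 6500 nM

Compound 1 and compound 2 differ in one place: fluoro in place of chloro on an aromatic carbon. That change produced a 7.5-fold higher number from compound 1 to compound 2 (0.88 log units; beyond the scatter). Compound 3 carries a different core; how its core differs from the core of compound 1 is not broken down here. Compound 4, `NC(=O)c1c(NC(=O)c2ccccc2F)sc2c1CCN(C(=S)Nc1cc(C(F)(F)F)cc(C(F)(F)F)c1)C2`, has not yet been measured. It differs from compound 3 by fluoro in place of chloro on an aromatic carbon, the same change seen between compound 1 and compound 2.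

From compound 3 to compound 4 a weakening is expected, estimated as a 4.0-fold higher number from compound 3 to compound 4 (0.60 log units; beyond the scatter), kept a little smaller than the earlier step because a 7.5-fold higher number from compound 1 to compound 2 (0.88 log units; beyond the scatter) rests on a single pair. Compound 4 is therefore estimated at 26000 nM, expected to lie between 10000 nM and 80000 nM in this assay.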

Compound 4, half-maximal inhibitory concentration: 17900 nM
Compound 4: the middle estimate sits 1.5-fold (0.16 log units) above what was measured; the measured number falls inside the stated range.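

In this assay, fluoro in place of chloro weakens inhibition again, with a 2.8-fold higher number from compound 3 to compound 4 (0.44 log units; beyond the scatter), so the direction of the change holds on both cores. The size of the step does not carry over unchanged: the same change on two cores in this assay, a 7.5-fold higher number (0.88 log units; beyond the scatter) from compound 1 to compound 2 and a 2.8-fold higher number (0.44 log units; beyond the scatter) from compound 3 to compound 4, 2.7-fold (0.44 log units) apart, beyond the scatter of two such steps. Two pairs cannot show what sets that size, since here the swap sits in the (2-chlorophenyl)carbonyl group, while in the earlier pair it lies elsewhere in the molecule, so the core and the site of the swap change together.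

The compounds shown leave open how a methyl group, a methoxy group or a plain hydrogen would compare at this place. They also leave open whether the same swap would weaken inhibition on a third core.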